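The source may report more compounds than this note shows. Statements on the series, on what has been measured and on what is new or still open speak of the compounds shown alone.

Compound 1, with the structure `CNC(=O)c1cc(C(=O)N[C@H]2CC[C@H](O)CC2)c([C@@H](C)c2cccc(C)c2)o1`, was measured in an ADME assay for permeability (a lower number here means that the compound crosses the layer more slowly, a higher number that the compound crosses the layer faster), and gave 85 nm/s, the lowest of the three numbers recorded. Compound 2, `CNC(=O)c1cc(C(=O)N[C@H]2[C@@H]3COC[C@@H]32)c([C@@H](C)c2ccccc2)o1`, gave 200 nm/s in this assay, and compound 3, `CNC(=O)c1cc(C(=O)N[C@H]2[C@@H]3C[C@@H](O)C[C@@H]32)n([C@@H](C)c2cccc(Cl)c2)n1`, gave 197 nm/s; each of these stands beyond the scatter above compound 1, and compound 2 and compound 3 lie within the scatter of each other. Compound 4, `CNC(=O)c1cc(C(=O)N[C@H]2CC[C@H](O)CC2)c([C@@H](C)c2cccc(Cl)c2)o1`, has not yet been measured. It differs from compound 1 only by chloro in place of methyl on an aromatic carbon. For the measured compounds named here, no measured pair here isolates this particular change, so its effect cannot be read from the data. For such a small swap the expected step from compound 1 to compound 4, a 1.3-fold higher number from compound 1 to compound 4 (0.11 log units; within the scatter), is modest and within the scatter, perhaps slightly upward. Compound 4 is therefore expected to give about 110 nm/s, within a range from 60 nm/s to 200 nm/s.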

Compound 4, apparent permeability: 150 nm/s
For compound 4 the middle estimate is 1.4-fold (0.13 log units) below the measured one; the range from low to high includes it.
By their numbers in this assay, from the lowest: compounds 1, 4, 3 and 2 (each within the scatter of the next, the first and the last beyond it).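

In this assay, for the compounds shown here, the pair gives the first direct reading of chloro in place of methyl on this aromatic carbon, meta to a large group: a step of a 1.8-fold higher number from compound 1 to compound 4 (0.25 log units; within the scatter). On the core of compound 1, this swap therefore stays within the usual scatter, and the 3-chlorophenyl and 3-methylphenyl compounds cannot be told apart. No measurement here offers an explanation for the size of this step. On these data alone, whether fluoro, methoxy or an amine at this place would also stay within the scatter remains open. So does whether the same swap would read alike on a different core.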